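The source may report more compounds than this note shows. Statements on the series, on what has been measured and on what is new or still open speak of the compounds shown alone.

Working notes on the series

The measured set comprises compound 1 `O=C(O)CCCSCCN1C(=O)OC[C@@H]1/C=C/[C@@H](O)Cc1ccccc1`, compound 2 `Cc1cccc(C[C@H](O)/C=C/[C@H]2CCC(=S)N2CCSCCCC(=O)O)c1` and compound 3 `CCc1cccc(C[C@H](O)/C=C/[C@H]2CSC(=O)N2CCSCCCC(=O)O)c1`, all read in an assay on CHO cells for displacement of a labelled ligand from prostaglandin E2 receptor EP3 subtype (Mus musculus), read by scintillation counting, with a stated time of 60 min; a higher number here means a weaker inhibitor, a lower number a stronger inhibitor. In this assay compound 1 gives 6400 nM, which is the highest number of the three. Compound 2 gives 980 nM, the nearest of the other two, and the gap from compound 1 to compound 2 lies beyond the scatter. Compound 3 gives 65 nM, the furthest of the three from compound 1, again beyond the scatter. Compound 1 thus stands as the weakest inhibitor among the measured compounds.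

The next compound, compound 4 `CCc1cccc(C[C@H](O)/C=C/[C@H]2COC(=O)N2CCSCCCC(=O)O)c1`, is not yet measured. Relative to compound 1 the change is ethyl in place of hydrogen on an aromatic carbon, meta to a large group, so that the benzyl end becomes a 3-ethylbenzyl. Among the compounds with values here, no pair of measured compounds that differ only in this way is available, so the size of the step is not fixed by a measured case; the two other measured compounds carry an alkyl on that ring and both give lower numbers than compound 1, though they differ from it in more than one place.

Compound 4 is expected to give a lower number than compound 1, and the step from compound 1 to compound 4 is estimated as a 7.1-fold lower number from compound 1 to compound 4 (0.85 log units; beyond the scatter). For compound 4 in this assay the estimate is 900 nM, with a range from 250 nM to 3000 nM.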

Compound 4, inhibition constant: 2700 nM
Beside the measured number, compound 4's estimate is 3.0-fold (0.48 log units) below it, within the range that was stated.
By their numbers in this assay, from the lowest: compound 3; then compound 2; then compound 4; then compound 1.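

Within the data shown here, this is the first step in which the ethyl stands alone: in this assay, ethyl in place of hydrogen on an aromatic carbon, turning benzyl into 3-ethylbenzyl, gives a 2.4-fold lower number from compound 1 to compound 4 (0.37 log units; beyond the scatter) as a modest change. The earlier compounds shown here with an alkyl on this ring differed from compound 1 in more than one place, so they could not fix the size of this change; this pair now does so, for the core of compound 1 only. No available measurement accounts for the size or direction of the step.

The compounds shown leave open how the number moves when a different group occupies this position, such as a longer chain like propyl, a methoxy group, a chlorine atom or an amine, and whether ethyl would give a similar step elsewhere on the aromatic ring. Among these compounds, they also leave open whether the same replacement of hydrogen by ethyl gives a step of similar size on another core, as no second pair differing only in this way is available.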